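Chloro for methoxy on the benzyl urea arm

The compounds below may be only part of what the source reports. "The series", "measured", "known", "first", "only" and "open" are said of these compounds alone.

Measured in an ADME assay on RAW264.7 cells (Mus musculus) for cytotoxicity, read by MTT assay, with a stated time of 48 h, tested at 100 uM (a lower number here means less inhibition, a higher number more inhibition at the concentration tested (going by the name of the read-out)), so far:
- compound 1, `COc1cnc2ccc(=O)n(CCN3CCC(NC(=O)NCc4ccc(Cl)cc4)CC3)c2c1`: 40.9%
- compound 2, `COc1ccc(CNC(=O)NC2CCN(CCn3c(=O)ccc4ncc(F)cc43)CC2)cc1`: 32.1%

Within the data shown here, only two compounds carry a number, and in this assay compound 2 and compound 1 lie within the usual scatter of each other, so no order between them can be read. Compound 2 is therefore simply one of two similar readings, with compound 1 as its nearest neighbour. No step between measured compounds is shown.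

Compound 3, `O=C(NCc1ccc(Cl)cc1)NC1CCN(CCn2c(=O)ccc3ncc(F)cc32)CC1`, is the next to be measured. Relative to compound 2 the change is chloro in place of methoxy on an aromatic carbon. Compound 1 already carries the 4-chlorobenzyl group, and its reading in this assay sits close to that of compound 2, which gives no ground to expect a shift beyond the scatter. The expected step from compound 2 is a number 3.9 percentage points higher from compound 2 to compound 3 (within the scatter), a change not beyond the scatter in either direction. For compound 3 the expected inhibition is 36%, estimated between 24% and 48%.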

Compound 3, a percentage reported as inhibition, at one concentration (the size of the read-out at that concentration, not a potency): 42.7%
Compound 3: middle estimate off by 6.7 percentage points, on the low side, within the range that was stated.
By their numbers in this assay, from the lowest: compounds 2, 1 and 3 (each within the scatter of the next, the first and the last beyond it).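

In this assay the aromatic carbon of the benzyl urea arm now has a direct one-place comparison: chloro in place of methoxy gives a number 10.6 percentage points higher from compound 2 to compound 3 (beyond the scatter), a modest step that clears the scatter. With the 4-chlorobenzyl group held constant, fluoro in place of methoxy on the core gives a number 1.8 percentage points higher from compound 1 to compound 3 (within the scatter), so that core change shows no readable effect in this single pair, and the benzyl arm is the only place seen here to shift the reading. Nothing available bears on the reason for the step.

As far as these compounds go, whether the chloro step also holds on the methoxy-bearing core remains open. So does the reading with an amine or a carboxylic acid on the same aromatic carbon.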